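The compounds below may be only part of what the source reports. "The series", "measured", "known", "first", "only" and "open" are said of these compounds alone.

In a functional assay on NCI-H1975 cells (Homo sapiens) for antiproliferative activity (a lower number here means a stronger inhibitor, a higher number a weaker inhibitor), the measured compounds stand as follows:
compound 1 `Cc1c2c(n3c1CCN(C)C[C@@H](C)[C@H](C)Nc1cc-3ccc1C(N)=O)CC(C)(C)CC2=O` gives 27 nM
compound 2 `COCCC(=O)N1CCc2c(C)c3c(n2-c2ccc(C(N)=O)c(c2)N[C@@H](C)[C@H](C)C1)CC(C)(C)CC3=O` gives 31 nM
compound 3 `Cc1c2c(n3c1CCN(C(=O)C(C)(C)N)C[C@@H](C)[C@H](C)Nc1cc-3ccc1C(N)=O)CC(C)(C)CC2=O` gives 21 nM

Compound 3 has the lowest of these three numbers, but it lies within the scatter of both neighbours (a 1.3-fold lower number from compound 1 to compound 3 (0.11 log units; within the scatter)) and (a 1.5-fold lower number from compound 2 to compound 3 (0.17 log units; within the scatter)). The compound still to be measured, compound 4 `Cc1c2c(n3c1CCN(C(=O)[C@H](C)O)C[C@@H](C)[C@H](C)Nc1cc-3ccc1C(N)=O)CC(C)(C)CC2=O`, keeps everything else and carries 1-hydroxyethyl in place of 1-amino-1-methylethyl on a carbonyl carbon.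

Among the compounds with values here, one measured step bears on this place directly, the exchange of the group on that same carbonyl carbon between compound 2 and compound 3 (a 1.5-fold lower number from compound 2 to compound 3 (0.17 log units; within the scatter)). Two others bear on it less directly, replacing methyl on an amine nitrogen in a ring with a carbonyl-bearing group (a 1.1-fold higher number from compound 1 to compound 2 (0.06 log units; within the scatter)) and (a 1.3-fold lower number from compound 1 to compound 3 (0.11 log units; within the scatter)). All three steps stayed within the scatter. Within the data shown here, no measured compound carries 1-hydroxyethyl, so the data offer no direct reading of this group. In this assay no step beyond the scatter is therefore expected, and no firm direction. The estimate amounts to a 1.2-fold higher number from compound 3 to compound 4 (0.09 log units; within the scatter) and so stays small. Compound 4 is expected at 26 nM (estimated range 12 nM to 55 nM).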

Compound 4, half-maximal inhibitory concentration: 52 nM
For compound 4 the middle estimate is 2.0-fold (0.30 log units) below the measured one, and the stated range covers the measured number.
By their numbers in this assay, from the lowest: compounds 3, 1, 2 and 4 (each within the scatter of the next, the first and the last beyond it).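

In this assay, within the data shown here, placing 1-hydroxyethyl in place of 1-amino-1-methylethyl on a carbonyl carbon whose other neighbours are amide-type nitrogen in a ring gives a 2.5-fold higher number from compound 3 to compound 4 (0.39 log units; beyond the scatter), the first step to pass beyond the scatter, so the group at this position can shift the read-out after all. The shift is visible against compound 3 alone, since the other two comparisons, a 1.7-fold higher number from compound 2 to compound 4 (0.22 log units; within the scatter) and a 1.9-fold higher number from compound 1 to compound 4 (0.28 log units; within the scatter), both stay within the scatter, and the 1-hydroxyethyl amide is therefore not separated from the 2-methoxyethyl amide or from the methyl on the ring nitrogen. Nothing available here accounts for the step.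

The compounds shown leave open whether the step follows the exchange of the amine for the hydroxyl or the smaller carbon count of the entering group, a question that 1-aminoethyl or 1-hydroxy-1-methylethyl on the same carbonyl carbon would settle. They also leave open how the opposite stereocentre of 1-hydroxyethyl, or a carboxylic acid at this place, would read in this assay.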